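The source may hold more compounds than are shown below. What is called first, only, known or untested is meant among the compounds shown, and "the series" means these compounds.

Measured in an in vitro assay on HEK385-7 cells for displacement of a labelled ligand from prostaglandin D2 receptor 2 (Homo sapiens); a lower number here means a stronger inhibitor, a higher number a weaker inhibitor:
compound 1 `O=C(O)Cc1sc(C(c2ccc(F)cc2)c2ccc(F)cc2)nc1-c1ccc(Cl)cc1`: 9.7 nM
compound 2 `O=C(O)Cc1sc(C(c2ccc(F)cc2)c2ccc(F)cc2)nc1-c1ccccc1`: 16 nM
compound 3 `O=C(O)Cc1sc(C(c2ccccc2)c2ccccc2)nc1-c1ccc(F)cc1`: 8.7 nM

All three numbers fall within the usual scatter of one another, so no order among them is drawn. Compound 1 and compound 2 share one core and differ in a single place, (chloro in place of hydrogen on an aromatic carbon); this change gave a 1.6-fold lower number from compound 2 to compound 1 (0.22 log units; within the scatter). Compound 3 stands on a different core, and its difference from compound 2 is not broken down here.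

Compound 4 `O=C(O)Cc1sc(C(c2ccccc2)c2ccc(Cl)cc2)nc1-c1ccc(F)cc1` has not yet been measured. It differs from compound 3 by chloro in place of hydrogen on an aromatic carbon, the same change as that seen between compound 2 and compound 1, at the same kind of place. In this assay the step from compound 3 is expected to be a 1.3-fold lower number from compound 3 to compound 4 (0.13 log units; within the scatter), a small shift of the same sense as the earlier one. This expectation rests on compound 1 and compound 2, because the step of a 1.6-fold lower number from compound 2 to compound 1 (0.22 log units; within the scatter) stayed inside the scatter and gives no reason to expect more here. Compound 4 is estimated at 6.5 nM, with a likely range from 3 nM to 14 nM.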

Compound 4, half-maximal inhibitory concentration: 14 nM
Beside the measured number, compound 4's estimate is 2.2-fold (0.33 log units) below it, within the range that was stated.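

In this assay, phenyl to 4-chlorophenyl on the core of compound 3 gave a 1.6-fold higher number from compound 3 to compound 4 (0.21 log units; within the scatter), and this step does not separate from the earlier chloro step on the other core: the same change on two cores in this assay, a 1.6-fold lower number (0.22 log units; within the scatter) from compound 2 to compound 1 and a 1.6-fold higher number (0.21 log units; within the scatter) from compound 3 to compound 4, 2.7-fold (0.42 log units) apart, within the scatter of two such steps. The opposite signs of the two steps therefore do not show that the change reverses from one core to the other, and they do not show that it carries over with a constant size either. The two cases show only that chloro in place of hydrogen stayed within the usual scatter on both cores, so neither step gives a usable size or direction for a further core in this series.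

Still open, going by these compounds, is whether a group other than chloro at this place, such as methoxy or trifluoromethyl, would give a step beyond the scatter. Also open, on these data alone, is whether an amine there would do so on either core.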